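A Second Bromo Group and the Expected Agonist Potency

This account rests on a few compounds, and the source may have more. Where it says the series, first, only, none or still open, it means among the compounds named here.

The three measured compounds, all tested in a functional assay on HEK293 cells for agonist activity at Neuronal acetylcholine receptor; alpha4/beta2 (Homo sapiens), read by FLIPR; on this read-out higher numbers stand for an effect only at larger amounts of compound and lower numbers for an effect already at smaller amounts:
compound 1, `c1cncc(N2CC[C@H]3CN[C@H]3C2)c1`, gives 71 nM
compound 2, `Brc1cncc(N2CC[C@H]3CN[C@H]3C2)c1`, gives 150 nM
compound 3, `Brc1cncc(N2CC[C@@H]3CN[C@@H]3C2)c1`, gives 1000 nM

Among these three numbers compound 2 stands second highest: compound 1 sits close, with a 2.1-fold higher number from compound 1 to compound 2 (0.32 log units; beyond the scatter), while compound 3 lies furthest away, with a 6.7-fold higher number from compound 2 to compound 3 (0.82 log units; beyond the scatter). The change from compound 2 to compound 3 is a matter of mirror-image configuration, as shown by the fact that compounds 2 and 3 differ only in the configuration as drawn, and is of a different kind from the change considered here.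

Compound 4, `Brc1cc(N2CC[C@H]3CN[C@H]3C2)cnc1Br`, differs from compound 2 by bromo in place of hydrogen on an aromatic carbon. Going by the values given here, the one measured step that bears on this is the earlier addition of a bromo group on an aromatic carbon, a 2.1-fold higher number from compound 1 to compound 2 (0.32 log units; beyond the scatter). A second bromo group is therefore expected to move the number in this assay by a similar modest amount in the same direction, upward. For compound 4 the estimated step is a 2.3-fold higher number from compound 2 to compound 4 (0.37 log units; beyond the scatter). Compound 4 is thus expected to give about 350 nM, within a range from 120 nM to 1200 nM.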

Compound 4, half-maximal effective concentration: 7.8 nM
Estimate against measurement, compound 4: 45-fold (1.65 log units) above; the measured number lies below the stated range.
By their numbers in this assay, from the lowest: compound 4; then compound 1; then compound 2; then compound 3.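

In this assay, placing a bromo group on the aromatic carbon next to the ring nitrogen, ortho to the existing bromo group, gives a 19-fold lower number from compound 2 to compound 4 (1.28 log units; beyond the scatter) and not the pattern of the earlier bromo step, which gave a 2.1-fold higher number from compound 1 to compound 2 (0.32 log units; beyond the scatter) on another carbon of the same ring. The same kind of change, bromo in place of hydrogen, therefore carries no fixed direction or size across this ring: at this place an effect appears at much smaller amounts of compound. Nothing measured here gives a reason for this large drop.

Going by these compounds, it remains open whether a chloro group, a methyl group or an amine at this place would move the number in the same way. On these data alone, it also remains open whether this bromo group would act alike on compound 1, without the first bromo group.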